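This account rests on a few compounds, and the source may have more. Where it says the series, first, only, none or still open, it means among the compounds named here.

Measured so far:
compound 1 `C=C1CC[C@@H]2[C@](C)(COC(C)=O)[C@H](OC(C)=O)CC[C@@]2(C)[C@H]1CC(Nc1ccc(S(=O)(=O)Nc2ccc(Cl)nn2)cc1)C1=CCOC1=O` — "not determined" (no result reported)
compound 2 `C=C1CC[C@@H]2[C@](C)(COC(C)=O)[C@H](OC(C)=O)CC[C@@]2(C)[C@H]1CC(Nc1ccc(S(=O)(=O)Nc2cc(C)on2)cc1)C1=CCOC1=O` — "not determined" (no result reported)
compound 3 `C=C1CC[C@@H]2[C@](C)(COC(C)=O)[C@H](OC(C)=O)CC[C@@]2(C)[C@H]1CC(Nc1ccc(S(=O)(=O)Nc2nccc(C)n2)cc1)C1=CCOC1=O` — > 100000 nM

Three compounds of the series share one core and differ only in the heteroaryl on the sulfonamide nitrogen. For compound 1 and compound 2 no result was reported in a functional assay on NCI-H226 cells (Homo sapiens) for inhibition, read by sulforhodamine B assay, with a stated time of 48 h; a higher number here means that more compound is tolerated, a lower number that less compound is tolerated. Going by the values given here, compound 3 is the only compound with an entry in this assay, and that entry is a limit of the assay rather than a number: > 100000 nM. Among the compounds with values here, the evidence on hand is therefore thin — the limit of > 100000 nM in this assay, at which 1 of the 3 values shown sits — and gives no step between measured compounds to lean on.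

Compound 4 `C=C1CC[C@@H]2[C@](C)(COC(C)=O)[C@H](OC(C)=O)CC[C@@]2(C)[C@H]1CC(Nc1ccc(S(=O)(=O)Nc2nccs2)cc1)C1=CCOC1=O` is yet to be measured. It differs from compound 3 in one place: 1,3-thiazol-2-yl in place of 4-methylpyrimidin-2-yl on a sulfonamide nitrogen. Nothing measured in the series shows what this exchange does to the read-out of this assay, so no direction can be read from the numbers; the only anchor is the limit reached by compound 3.

On that basis compound 4 is expected to sit where compound 3 sits, most likely again reported as a limit, with the expected step from compound 3 to compound 4 in this assay being none beyond the scatter, a number no higher from compound 3 to compound 4 (the limit leaves the size open). The estimate for compound 4 is 100000 nM, within a range of 30000 nM to 300000 nM.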

Compound 4, concentration lethal to 50% of the cells: > 100000 nM
Compound 4: a limit, no number (the forecaster's own chance of this, stated with the estimate: 80%); the middle value lies on the limit itself.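

In this assay compound 3 gives > 100000 nM, a limit. Compound 4 gives > 100000 nM, also a limit, so no step can be read between compound 3 and compound 4. Still open, as far as these compounds go, is whether any heteroaryl on the sulfonamide nitrogen gives a number in this assay, and what 1,3-thiazol-2-yl in place of 4-methylpyrimidin-2-yl does to the read-out.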